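Bromo to Methoxy on a Shared Core

A few compounds are considered here, and "the series" means these few. Any claim that something is new, unique, unknown or untested is made for them only; others in the source may bear on it.

- Compound 1, `COc1ccc(/C=C2\CCC/C(=C\c3cccc(Cl)c3)C2=O)cc1OC`: 11900 nM
- Compound 2, `COc1ccc(/C=C2\CCC/C(=C\c3cccc(Br)c3)C2=O)cc1OC`: 12400 nM

In an ADME assay on NHDF cells (Homo sapiens) for cytotoxicity, read by MTT assay, with a stated time of 72 h (on this read-out lower numbers stand for stronger inhibition and higher numbers for weaker inhibition), compound 2 sits level with compound 1, their values lying within the scatter of each other. Compound 3, `COc1cccc(/C=C2\CCC/C(=C\c3ccc(OC)c(OC)c3)C2=O)c1`, differs from compound 2 as follows: methoxy in place of bromo on an aromatic carbon. Among the compounds with values here, the one measured step, a 1.0-fold higher number from compound 1 to compound 2 (0.02 log units; within the scatter), puts bromo in place of chloro and stays within the scatter. Within the data shown here, no measured step involves methoxy, so the expectation rests on compound 2 at 12400 nM, with no change beyond the scatter expected. The expected step is a 1.0-fold higher number from compound 2 to compound 3 (0.00 log units; within the scatter). For compound 3 the estimate is 12500 nM, with an expected range of 6000 nM to 25000 nM.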

Compound 3, half-maximal inhibitory concentration: 11600 nM
The estimate for compound 3 lay 1.1-fold (0.03 log units) above the measured number, and the stated range covers the measured number.
By their numbers in this assay, from the lowest: compounds 3, 1 and 2 (each within the scatter of the next).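

In this assay methoxy in place of bromo gives a 1.1-fold lower number from compound 2 to compound 3 (0.03 log units; within the scatter) and methoxy in place of chloro gives a 1.0-fold lower number from compound 1 to compound 3 (0.01 log units; within the scatter) at the same place on the ring. The reading here therefore stays level not only from one halogen to another but also when a halogen gives way to methoxy, a group of two heavy atoms with a hydrogen-bond acceptor. Nothing available explains this flat result. Going by these compounds, whether an amine or a carboxylic acid at this place would shift the number beyond the scatter remains open.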